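Swapping the para substituent on the phenoxy ring

This account rests on a few compounds, and the source may have more. Where it says the series, first, only, none or still open, it means among the compounds named here.

Compound 2 `COc1ccc(OC(C)(C)C2OCC(C/C=C\CCC(=O)O)C(c3cccnc3)O2)cc1` carries a 4-methoxyphenoxy group on the shared core. Among the measured compounds shown here, in an assay for inhibition of Thromboxane-A synthase (Homo sapiens), using microsomes (on this read-out lower numbers stand for stronger inhibition and higher numbers for weaker inhibition), compound 2 gives 41 nM, the highest of the two numbers measured so far. For the measured compounds named here, its only neighbour is compound 1 `CSc1ccc(OC(C)(C)C2OCC(C/C=C\CCC(=O)O)C(c3cccnc3)O2)c([N+](=O)[O-])c1`, which in this assay gives 22 nM; the step of a 1.9-fold higher number from compound 1 to compound 2 (0.27 log units; within the scatter) exchanges one aromatic substitution pattern for another and stays within the scatter.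

Compound 3 `CC(C)(C)c1ccc(OC(C)(C)C2OCC(C/C=C\CCC(=O)O)C(c3cccnc3)O2)cc1` differs from compound 2 by tert-butyl in place of methoxy on an aromatic carbon, para to a large group. Going by the values given here, the single measured step that bears on this, the one from compound 1 to compound 2, changed the substituents on the same ring and left the number within the scatter. Among the compounds with values here, no measured pair tests tert-butyl itself, so the expectation rests on that one comparison alone. The step from compound 2 to compound 3 is therefore expected to be small, a 1.1-fold higher number from compound 2 to compound 3 (0.04 log units; within the scatter), with no clear direction. Compound 3 is expected to give about 45 nM in this assay, within a range from 15 nM to 150 nM.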

Compound 3, half-maximal inhibitory concentration: 280 nM
For compound 3 the middle estimate is 6.2-fold (0.79 log units) below the measured one, outside the stated range (above it).
By their numbers in this assay, from the lowest: compounds 1 and 2 (each within the scatter of the next); then compound 3.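

In this assay, among the compounds shown here, this position on the phenoxy ring proves sensitive to what it carries: placing tert-butyl in place of methoxy on an aromatic carbon, para to a large group, gives a 6.8-fold higher number from compound 2 to compound 3 (0.83 log units; beyond the scatter) and so moves the number beyond the scatter, which the one earlier step on this ring did not do. Measured against the substituted aryl group of compound 1, the 4-(tert-butyl)phenyl group gives a 13-fold higher number from compound 1 to compound 3 (1.10 log units; beyond the scatter). This sets compound 3 clearly apart from compounds 1 and 2, whose own numbers lie within the scatter of each other. Nothing available explains why this exchange weakens inhibition so much when the earlier one left the number within the scatter.

The compounds shown leave open how the number responds to other groups on this aromatic carbon, such as methyl, isopropyl, chlorine or an amine, and therefore whether tert-butyl stands alone or marks the end of a gradual series. On these data alone, they also do not separate the nitro and methylthio groups of compound 1, so the contribution of each to its number remains unknown.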